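From Fluoro to Pentyl on a Shared Core

A few compounds are considered here, and "the series" means these few. Any claim that something is new, unique, unknown or untested is made for them only; others in the source may bear on it.

Of the compounds shown here, two have so far been tested in an assay on isolated protein for inhibition of Aromatase (Homo sapiens), read by fluorescence, using NADPH, with a stated time of 30 min, tested at 50 uM; a higher number here means more inhibition at the concentration tested (going by the name of the read-out), a lower number less inhibition. Compound 1 `C(=N/OCc1ccccc1)\c1c(-c2ccccc2)[nH]c2ccccc12` gives 23.3%. Compound 2 `Fc1ccc(-c2cc3ccccc3[nH]2)cc1` gives 21.8%, the lower of the two numbers, yet the gap to compound 1 lies within the scatter, so the two cannot be told apart. Compound 3 `CCCCCc1ccc(-c2cc3ccccc3[nH]2)cc1` has not been measured; it differs from compound 2 by pentyl in place of fluoro on an aromatic carbon. Among the compounds with values here, with no measured step between compounds to guide the guess, only a small rise is expected, a number 8.2 percentage points higher from compound 2 to compound 3 (within the scatter), hardly beyond the scatter. Compound 3 is therefore estimated at 30%, with a range from 15% to 50%.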

Compound 3, a percentage reported as inhibition, at one concentration (the size of the read-out at that concentration, not a potency): 0%
Compound 3: middle estimate off by 30 percentage points, on the high side; measured number below the stated range.
By their numbers in this assay, from the lowest: compound 3; then compounds 2 and 1 (each within the scatter of the next).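

Within the data shown here, replacing fluoro with pentyl on this aromatic carbon gives a number 21.8 percentage points lower from compound 2 to compound 3 (beyond the scatter), the first sign that the group at this place can change the read-out. With compound 3 at 0%, this larger group goes with a loss of measurable inhibition at the concentration tested, not a gain. The data offer no measurement that explains this drop.

The compounds shown leave open how a methyl group, a propyl chain or an amine on the same carbon would compare. It also remains unclear whether inhibition falls gradually or abruptly between fluoro and pentyl.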